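Methyl for Hydrogen on the Chain Carbon of Compound 2

A few compounds are considered here, and "the series" means these few. Any claim that something is new, unique, unknown or untested is made for them only; others in the source may bear on it.

Compound 2 `CC(C(=O)N1CCN(c2ccccc2C(F)(F)F)CC1)N1C(=O)CCC1=O` stands highest of the two compounds measured in a functional assay on the whole organism (strain Swiss) with Mus musculus as the target, in the maximal electroshock model, with a stated time of 1 h, at a dose of 300 mg/kg by the intraperitoneal route (a lower number here means a weaker effect, a higher number a stronger effect of the compound at the dose given), where compound 2 gives 75%. Compound 1 `CCC(C(=O)N1CCN(c2ccccc2Cl)CC1)N1C(=O)CCC1=O` gives 50% in this assay, a number beyond the scatter lower; since the two structures differ in more than one place, the numbers are only set side by side. Compound 3 `CCC(C(=O)N1CCN(c2ccccc2C(F)(F)F)CC1)N1C(=O)CCC1=O` differs from compound 2 by methyl in place of hydrogen on a saturated chain carbon, two bonds along the chain from an amide-type nitrogen in a ring and a carbonyl carbon. Among the compounds with values here, no measured pair isolates this change, so a small downward step or none beyond the scatter is expected in this assay. For compound 3 the estimate is 62%, between 30% and 90%, expected as a step of a number 13 percentage points lower from compound 2 to compound 3 (beyond the scatter).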

Compound 3, a percentage reported as activity, at one dose (the size of the read-out at that dose, not a potency): 0%
Beside the measured number, compound 3's estimate is 62 percentage points above it, outside the stated range (below it).
By their numbers in this assay, from the lowest: compound 3; then compound 1; then compound 2.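

In this assay, this saturated chain carbon proves highly sensitive: methyl in place of hydrogen gives a number 75 percentage points lower from compound 2 to compound 3 (beyond the scatter), the first step read from a pair differing in one place. Trifluoromethyl in place of chloro on an aromatic carbon gives a number 50 percentage points lower from compound 1 to compound 3 (beyond the scatter), so the aromatic substituent also matters when the chain carries ethyl. Nothing at hand explains either step. The compounds shown leave open how a longer chain such as propyl, or an amine, would fare on this carbon. They also leave open whether chloro would give a similar result with the methyl chain of compound 2.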